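The source may report more compounds than this note shows. Statements on the series, on what has been measured and on what is new or still open speak of the compounds shown alone.

In a functional assay on MCF7 cells (Homo sapiens) for cytotoxicity, read by MTT assay, with a stated time of 72 h (on this read-out higher numbers stand for weaker inhibition and lower numbers for stronger inhibition), compound 1 `COc1ccccc1/C=C1\CCC/C(=C\c2ccc(OC)c(OC)c2)C1=O` gives 8000 nM. In place of the 2-methoxyphenyl of compound 1, compound 2 `COc1ccc(/C=C2\CCC/C(=C\c3ccc(OC)c(OC)c3)C2=O)cc1` carries 4-methoxyphenyl and gives 7800 nM. This swap amounts to a 1.0-fold lower number from compound 1 to compound 2 (0.01 log units; within the scatter), so compound 2 stands level with compound 1, and the two numbers cannot be told apart.

Compound 3 `COc1ccc(/C=C2\CCC/C(=C\c3ccc(OC)c(OC)c3)C2=O)c(OC)c1` keeps all of compound 2 and gains one group: methoxy in place of hydrogen on an aromatic carbon. In words, this is methoxy in place of hydrogen on an aromatic carbon, ortho to a large group and meta to a methoxy group. Compound 3 therefore carries on that ring the methoxy groups of both compound 1 and compound 2.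

Among the measured compounds shown here, the only measured step that bears on this is a 1.0-fold lower number from compound 1 to compound 2 (0.01 log units; within the scatter). For the measured compounds named here, that step swaps one group for another, and no measured pair shows what adding a group does, so it is a weak guide and the range must stay wide. In this assay, no step beyond the scatter is expected. The estimated change is a 1.1-fold lower number from compound 2 to compound 3 (0.05 log units; within the scatter). For compound 3, the estimate is 7000 nM, with an expected range of 3000 nM to 16000 nM.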

Compound 3, half-maximal inhibitory concentration: 15600 nM
Compound 3: middle estimate off by 2.2-fold (0.35 log units), on the low side; low and high end bracket the measured number.
By their numbers in this assay, from the lowest: compounds 2, 1 and 3 (each within the scatter of the next).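

Adding methoxy in place of hydrogen on an aromatic carbon, ortho to a large group and meta to a methoxy group, gives a 2.0-fold higher number from compound 2 to compound 3 (0.30 log units; within the scatter) in this assay, and the matching comparison gives a 2.0-fold higher number from compound 1 to compound 3 (0.29 log units; within the scatter). Among the compounds shown here, the earlier pair showed only one group swapped for another, whereas these steps show that a ring carrying both methoxy groups cannot be told apart in this read-out from a ring carrying either one alone, although both steps lie within the scatter and cannot establish a real loss of activity. No measurement here offers an explanation for these numbers, so the result stands as a plain observation.

The compounds shown leave open whether this place responds at all to a group other than methoxy, such as a hydroxyl, an amine, a carboxylic acid or a longer chain like ethoxy. They also leave open whether the same addition would read the same way with a different group on the other side of the shared core, such as a bare phenyl ring in place of the dimethoxyphenyl.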